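This account rests on a few compounds, and the source may have more. Where it says the series, first, only, none or still open, it means among the compounds named here.

Within the data shown here, in a functional assay on UACC-257 cells (Homo sapiens) for inhibition, read by sulforhodamine B assay, with a stated time of 48 h (on this read-out lower numbers stand for stronger inhibition and higher numbers for weaker inhibition), compound 1 (`CN1CCCN(CCNc2nccc(-c3c(-c4cccc(O)c4)nc4sccn34)n2)S1(=O)=O`) gives 8210 nM and compound 2 (`O=S(=O)(NCCCNc1nccc(-c2c(-c3cccc(O)c3)nc3sccn23)n1)c1cccc(F)c1`) gives 2850 nM as the lower of the two numbers so far. Compound 3 (`O=S(=O)(NCCNc1nccc(-c2c(-c3cccc(O)c3)nc3sccn23)n1)c1ccc(F)cc1`) is not yet measured and differs from compound 2 by this change (((4-fluorophenyl)sulfonyl)amino in place of (((3-fluorophenyl)sulfonyl)amino)methyl on a saturated chain carbon, two bonds along the chain from a nitrogen on an aromatic ring). Among the measured compounds shown here, the sole measured step (a 2.9-fold lower number from compound 1 to compound 2 (0.46 log units; beyond the scatter)) is modest and replaces a different group at the same place, so it sets no direction here, and no step beyond the scatter is expected in this assay for this change. The expected step is small (a 1.1-fold higher number from compound 2 to compound 3 (0.02 log units; within the scatter)). For compound 3 the estimated value is 3000 nM with a range of 1200 nM to 7500 nM in this estimate.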

Compound 3, half-maximal inhibitory concentration: 568 nM
Compound 3: middle estimate off by 5.3-fold (0.72 log units), on the high side; measured number below the stated range.
By their numbers in this assay, from the lowest: compound 3; then compound 2; then compound 1.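

At this saturated chain carbon, the swap between the two fluorophenyl sulfonyl groups is not neutral in this assay: a 5.0-fold lower number from compound 2 to compound 3 (0.70 log units; beyond the scatter). Against the six-membered non-aromatic ring group, ((4-fluorophenyl)sulfonyl)amino gains more, with a 14-fold lower number from compound 1 to compound 3 (1.16 log units; beyond the scatter). No measurement bearing on the cause of these steps is available.

The step from compound 2 to compound 3 changes the methyl and the fluorine position together, and the compounds shown do not separate the two. From the compounds shown here alone, how an amine or a carboxylic acid would read in place of the fluorophenyl group remains open.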